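Swapping an Aryl Group: Expected Cytotoxicity of Compound 4

The compounds below may be only part of what the source reports. "The series", "measured", "known", "first", "only" and "open" are said of these compounds alone.

Of the compounds shown here, three have been measured in an ADME assay on Vero cells (Chlorocebus sabaeus) for cytotoxicity, read by MTT assay, tested at 25 uM; a lower number here means a stronger effect, a higher number a weaker effect of the compound at the concentration tested. Among the compounds with values here, compound 1 `CSc1ccc(C(=O)/C(=C/c2cc3ccccc3s2)c2ccc(Cl)c(Cl)c2)cc1` gives 93.4%, and compound 2 `CSc1ccc(C(=O)/C(=C/c2ccccn2)c2ccc(Cl)c(Cl)c2)cc1` gives 97.9%; the one step between them, a number 4.5 percentage points higher from compound 1 to compound 2 (within the scatter), stays within the scatter. Compound 3 `CCOC(=O)C(C(=O)c1ccc(OC)cc1)C(NC(C)=O)c1ccc(C(C)C)cc1` gives 98.8%, and the values of compound 2 and compound 1 both lie within the usual scatter of that number, so the three compounds cannot be told apart in this assay. All three numbers sit near the top of the scale, meaning the cells were barely affected at the concentration tested.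

Compound 4 `CCOC(=O)C(C(=O)c1ccc(OC)cc1)C(NC(C)=O)c1cccc2ccccc12` differs from compound 3 in one place: naphthalen-1-yl in place of 4-isopropylphenyl on a saturated chain carbon bound to an amide-type nitrogen and a saturated chain carbon. Within the data shown here, no measured step touches this position or this pair of groups; the only measured step concerns a different position on a different core and was itself within the scatter. Compound 4 is therefore expected to show no step beyond the scatter, a number 2.8 percentage points lower from compound 3 to compound 4 (within the scatter), and its value in this assay is estimated at 96%, lying between 85% and 100%.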

Compound 4, a percentage reported as activity, at one concentration (the size of the read-out at that concentration, not a potency): 99.2%
Compound 4: middle estimate off by 3.2 percentage points, on the low side, within the range that was stated.
By their numbers in this assay, from the lowest: compounds 1, 2, 3 and 4 (each within the scatter of the next).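

In this assay, within the data shown here, naphthalen-1-yl in place of 4-isopropylphenyl on a saturated chain carbon bound to an amide-type nitrogen and a saturated chain carbon gives a number 0.4 percentage points higher from compound 3 to compound 4 (within the scatter), the first measured step at this position. The entering group has 2 six-membered aromatic rings and 10 heavy atoms, the leaving group one such ring and 9, yet the two compounds cannot be told apart in this read-out, so this exchange of carbon-only aromatic groups shows no measurable effect here. Nothing available bears on the reason for this result.

From the compounds shown here alone, both groups contain only carbon, so it remains open whether an amine or a carboxylic acid on this aromatic group would change the number. Going by these compounds, it also remains open whether any change at this position on this core can bring the number down from the top of the scale.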